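The source may hold more compounds than are shown below. What is called first, only, known or untested is meant among the compounds shown, and "the series" means these compounds.

Measured compounds:
compound 1 `CCn1cc(C(=O)C(=O)Nc2ccc(OC)nc2)c2ccccc21` — 219 nM
compound 2 `COc1ccc(NC(=O)C(=O)c2cn(C(C)C)c3ccccc23)cn1` — 85 nM
compound 3 `COCCn1cc(C(=O)C(=O)Nc2ccc(OC(C)(C)C)nc2)c2ccccc21` — 858 nM

The three measured compounds were tested in a functional assay on FaDu cells (Homo sapiens) for cytotoxicity, read by MTT assay, with a stated time of 72 h; on this read-out lower numbers stand for higher toxicity in this test and higher numbers for lower toxicity in this test. Compound 2 gives 85 nM, compound 1 gives 219 nM, and compound 3 gives 858 nM. Among the measured compounds shown here, the only single-place step among them is a 2.6-fold higher number from compound 2 to compound 1 (0.41 log units; beyond the scatter), the change being (hydrogen in place of methyl on a saturated chain carbon bound to an aromatic nitrogen and a saturated chain carbon). Compound 3 shares the core of compound 2, but the difference between the two cores is not broken down here; the values show that compound 3 stands at a higher number than both compound 1 and compound 2.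

Compound 4 `COCCn1cc(C(=O)C(=O)Nc2ccc(OC(C)C)nc2)c2ccccc21` has not yet been measured in this assay. It differs from compound 3 by hydrogen in place of methyl on a saturated chain carbon bound to an oxygen on an aromatic ring and two saturated chain carbons. For the measured compounds named here, this is the same kind of change as the one from compound 2 to compound 1, but not the same: there the place was on a saturated chain carbon bound to an aromatic nitrogen and a saturated chain carbon, whereas here it is on a saturated chain carbon bound to an oxygen on an aromatic ring and two saturated chain carbons. The earlier step gives a modest rise in the number, yet it sits in a different part of the molecule, and compound 1, which carries the smaller alkoxy group, gives 219 nM, a lower number than compound 3. With these two cues pulling in opposite directions, compound 4 is expected to stay close to compound 3, with a step of a 1.2-fold lower number from compound 3 to compound 4 (0.09 log units; within the scatter) estimated. Compound 4 is estimated at 700 nM, with a likely range from 250 nM to 2000 nM.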

Compound 4, concentration lethal to 50% of the cells: 55 nM
Compound 4: the middle estimate sits 13-fold (1.10 log units) above what was measured; the whole stated range lies above it.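

In this assay, the change from tert-butoxy to isopropoxy gives a 16-fold lower number from compound 3 to compound 4 (1.19 log units; beyond the scatter), a large step, and it does not match the earlier step in size or direction: the same change on two cores in this assay, a 2.6-fold higher number (0.41 log units; beyond the scatter) from compound 2 to compound 1 and a 16-fold lower number (1.19 log units; beyond the scatter) from compound 3 to compound 4, 40-fold (1.60 log units) apart, beyond the scatter of two such steps This shows that, in this series, the effect of hydrogen in place of methyl cannot be carried from one core to another, since even the direction of the step does not hold. It does not show what lies behind the gap, as the earlier step sits on a saturated chain carbon bound to an aromatic nitrogen and a saturated chain carbon, the new one sits on a saturated chain carbon bound to an oxygen on an aromatic ring and two saturated chain carbons, and the compounds shown cannot separate the place of the change from the core that carries it.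

The compounds shown leave open whether tert-butoxy to isopropoxy would give a similar step on the core of compound 1 or compound 2. They also leave open how an ethoxy group, a longer alkoxy chain or an amine in place of the isopropoxy of compound 4 would read in this assay.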